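Methoxy in place of fluoro on the sulfonamide ring

The source may hold more compounds than are shown below. What is called first, only, known or untested is meant among the compounds shown, and "the series" means these compounds.

Compound 1 `Cc1ccc(N2CCc3c(NS(=O)(=O)c4cccc(C(F)(F)F)c4)n[nH]c3C2=O)cc1` gives 3280 nM in a functional assay on HeLa cells for antagonist activity at 5-hydroxytryptamine receptor 6 (Homo sapiens), read by cAMP accumulation, with stated times of 10 min and 30 min; a lower number here means a stronger inhibitor, a higher number a weaker inhibitor. Compound 2 `COc1cccc(S(=O)(=O)Nc2n[nH]c3c2CCN(c2ccc(C)cc2)C3=O)c1` gives 6770 nM. Compound 3 `COc1ccc(N2CCc3c(NS(=O)(=O)c4cccc(F)c4)n[nH]c3C2=O)cc1` gives 580 nM.

Compound 3 stands lowest of the three numbers in this assay. Compound 4 `COc1ccc(N2CCc3c(NS(=O)(=O)c4cccc(OC)c4)n[nH]c3C2=O)cc1` differs from it in one place: methoxy in place of fluoro on an aromatic carbon. Among the measured compounds shown here, the one measured step that bears on this change is a 2.1-fold higher number from compound 1 to compound 2 (0.31 log units; beyond the scatter), where a methoxy also entered this ring, though in place of trifluoromethyl rather than fluoro. On that basis a modest rise in the number is expected, of about the same size: a 2.1-fold higher number from compound 3 to compound 4 (0.32 log units; beyond the scatter). Compound 4 is therefore estimated at 1200 nM, with a range from 500 nM to 3000 nM.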

Compound 4, half-maximal inhibitory concentration: 7080 nM
The estimate for compound 4 lay 5.9-fold (0.77 log units) below the measured number; the measured number lies above the stated range.
By their numbers in this assay, from the lowest: compound 3; then compound 1; then compounds 2 and 4 (each within the scatter of the next).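

On the sulfonamide ring, methoxy in place of fluoro gives a 12-fold higher number from compound 3 to compound 4 (1.09 log units; beyond the scatter), so the modest step seen earlier for methoxy in place of trifluoromethyl does not carry over to this pair. Methoxy in place of methyl on the other aromatic ring gives a 1.0-fold higher number from compound 2 to compound 4 (0.02 log units; within the scatter), so with a 3-methoxyphenyl group present that change makes no measurable difference. Nothing available explains why the fluoro to methoxy step is so large. Open, going by these compounds, is whether a chlorine, a nitrile or an amine at this place would stay close to fluoro or fall back towards methoxy.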